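Methyl in place of fluoro on the fused ring

The source may report more compounds than this note shows. Statements on the series, on what has been measured and on what is new or still open speak of the compounds shown alone.

Compound 1 `Cc1ccc2nc(NC(=O)c3cn(-c4ccccc4)nc3-c3ccc(F)cc3)sc2c1`: in a functional assay on PC-3 cells (Homo sapiens) for cytotoxicity, read by MTT assay, with a stated time of 72 h (a higher number here means a weaker inhibitor, a lower number a stronger inhibitor), compound 1 gives 20500 nM.
Compound 2 `O=C(Nc1nc2ccccc2s1)c1cn(-c2ccccc2)nc1-c1ccc(Cl)cc1`: in this assay compound 2 gives 7750 nM.
Compound 3 `O=C(Nc1nc2ccc(F)cc2s1)c1cn(-c2ccccc2)nc1-c1ccc(Cl)cc1`: in this assay compound 3 gives 5790 nM.

Compound 3 has the lowest of the three numbers; compound 2 lies within the scatter of it, while compound 1 stands further off. Compound 4 `Cc1ccc2nc(NC(=O)c3cn(-c4ccccc4)nc3-c3ccc(Cl)cc3)sc2c1` differs from compound 3 by one change: methyl in place of fluoro on an aromatic carbon. Going by the values given here, the only measured step at this place is a 1.3-fold lower number from compound 2 to compound 3 (0.13 log units; within the scatter), and it concerns hydrogen rather than methyl, so it bears on the present change only loosely. Among the compounds with values here, no measured pair shows methyl entering in place of fluoro; compound 1 carries the methyl but also a different halogen on the pendant ring, so its value alone cannot be read as this step. With so little to go on, a modest rise, near the edge of the scatter, is expected: a 1.6-fold higher number from compound 3 to compound 4 (0.19 log units; within the scatter). Compound 4 is therefore estimated at 9000 nM, within 4000 nM to 22000 nM.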

Compound 4, half-maximal inhibitory concentration: 14500 nM
Estimate against measurement, compound 4: 1.6-fold (0.21 log units) below; low and high end bracket the measured number.
By their numbers in this assay, from the lowest: compounds 3, 2, 4 and 1 (each within the scatter of the next, the first and the last beyond it).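

Methyl in place of fluoro at this position gives a 2.5-fold higher number from compound 3 to compound 4 (0.40 log units; beyond the scatter) in this assay, so these two groups do separate here. Methyl in place of hydrogen gives only a 1.9-fold higher number from compound 2 to compound 4 (0.27 log units; within the scatter), and chloro in place of fluoro on the other ring gives a 1.4-fold lower number from compound 1 to compound 4 (0.15 log units; within the scatter), so neither change separates its pair. No measurement available here explains the gap between methyl and fluoro.

Going by these compounds, what an amine, a methoxy group or a longer chain would do at this position remains open.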